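Benzyloxy benzamide series: piperazine swap and kinetic solubility

This account rests on a few compounds, and the source may have more. Where it says the series, first, only, none or still open, it means among the compounds named here.

Two members of the series carry measured values and one awaits measurement. Compound 1 has the structure `O=C(Nc1cccc(F)c1)c1cc(C(F)(F)F)ccc1OCc1ccc(F)cc1`, compound 2 the structure `CN1CCC(c2ccc(OCc3ccccc3)c(C(=O)Nc3ccnnc3)c2)CC1`, and compound 3, not yet measured, the structure `O=C(Nc1ccnnc1)c1cc(N2CCNCC2)ccc1OCc1ccccc1`. In a physicochemical assay for solubility, measured as kinetic solubility (on this read-out lower numbers stand for lower solubility and higher numbers for higher solubility), compound 2 gives 71000 nM, the only plain number shown in the set. Compound 1 gives in this assay < 1000 nM, which is a limit of the assay and not a number. On the evidence side: the limit of < 1000 nM in this assay, at which 1 of the 2 values shown sits. Going by the values given here, compound 2 therefore stands alone as the single numerical reference point, and no measured step between two compounds differing in one place exists.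

Compound 3 is derived from compound 2 by piperazin-1-yl in place of 1-methylpiperidin-4-yl on an aromatic carbon. With no measured step of this kind shown, the expected step from compound 2 to compound 3 in this assay, a 1.3-fold higher number from compound 2 to compound 3 (0.10 log units; within the scatter), is taken to be small and not clearly beyond the scatter, leaning if anything toward a higher reading. Compound 3 is accordingly expected to give about 90000 nM in this assay, with a range from 35000 nM to 230000 nM.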

Compound 3, solubility: 98000 nM
Estimate against measurement, compound 3: 1.1-fold (0.04 log units) below; measured number inside the range.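

Going by these compounds alone, on the aromatic carbon meta to the (pyridazin-4-yl)carbamoyl group and para to the benzyloxy group, the first measured exchange, piperazin-1-yl in place of 1-methylpiperidin-4-yl, gives in this assay a 1.4-fold higher number from compound 2 to compound 3 (0.14 log units; within the scatter), so the two compounds are not separated on this read-out. The exchange removes the N-methyl-bearing ring carbon framework and brings in a second ring nitrogen and a hydrogen-bond donor, and at this position these differences in the six-membered ring leave no reading beyond the scatter. No measured information shown here accounts for the size of this step.

On these data alone, whether a morpholin-4-yl ring, a 4-methylpiperazin-1-yl group, an open-chain amine or a carboxylic acid at the same carbon would read alike remains open. The series shown also holds no single-place step at this position that lies beyond the scatter, so how far the reading on this assay can move with the group at this carbon is still undefined.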